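Swapping the aryl group on a sulfonamide nitrogen

The compounds below may be only part of what the source reports. "The series", "measured", "known", "first", "only" and "open" are said of these compounds alone.

Compound 1 `CCc1ccc(NS(=O)(=O)c2ccc(N3CCNC3=O)cc2)cc1`: 810 nM
Compound 2 `O=C1NCCN1c1ccc(S(=O)(=O)Nc2ccc(C3CCCCC3)cc2)cc1`: > 1000 nM

Among the measured compounds shown here, compound 1, with the structure `CCc1ccc(NS(=O)(=O)c2ccc(N3CCNC3=O)cc2)cc1`, is the only member of this set with a definite number: in a functional assay on MCF7 cells (Homo sapiens) for antiproliferative activity, read by sulforhodamine B assay, with a stated time of 48 h (a higher number here means a weaker inhibitor, a lower number a stronger inhibitor), compound 1 gives 810 nM. Compound 2, with the structure `O=C1NCCN1c1ccc(S(=O)(=O)Nc2ccc(C3CCCCC3)cc2)cc1`, does not; in this assay compound 2 reaches only the limit > 1000 nM, which is a limit of the measurement and not a number. For the measured compounds named here, the one measured step, an at least 1.2-fold higher number from compound 1 to compound 2 (0.09 log units; that floor lies within the scatter), is therefore open-ended and cannot be placed above the scatter with confidence, the more so because of the limit of > 1000 nM in this assay, at which 1 of the 2 values shown sits.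

Compound 3, with the structure `Cc1cccc(NS(=O)(=O)c2ccc(N3CCNC3=O)cc2)c1C`, changes compound 1 at a different position. The change is 2,3-dimethylphenyl in place of 4-ethylphenyl on a sulfonamide nitrogen. Going by the values given here, no measured step in this set touches the arrangement of the substituents on that aryl group, so nothing here points to a large shift in either direction. The step of a 1.1-fold higher number from compound 1 to compound 3 (0.05 log units; within the scatter) is therefore expected to stay near the scatter. Compound 3 is expected to give about 900 nM, with a range from 400 nM to 2500 nM.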

Compound 3, half-maximal inhibitory concentration: 230 nM
For compound 3 the middle estimate is 3.9-fold (0.59 log units) above the measured one, outside the stated range (below it).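

In this assay the set now holds a change on the sulfonamide nitrogen that lies beyond the scatter (a 3.5-fold lower number from compound 1 to compound 3 (0.55 log units; beyond the scatter)), which the open-ended step to compound 2 could not show. The 4-ethylphenyl and 2,3-dimethylphenyl groups have the same count of heavy atoms, both are a single aromatic ring of carbon only, and neither carries a hydrogen-bond donor or acceptor, so the lower number comes with a rearrangement of the same carbons and not with any added atom. Among the compounds shown here, this position therefore responds to how the carbons are arranged on the aryl group, although this rests on the single pair of compound 1 and compound 3 and no wider pattern can be claimed from it.

The value of compound 2 is a limit and not a number, so the step to its cyclohexyl group has no measured size: the limit of > 1000 nM in this assay, at which 1 of the 3 values shown sits. Going by these compounds, it also stays open whether a single methyl group, or an amine or a carboxylic acid on that aryl ring, would keep the lower number of compound 3.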